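Acyl exchange on the shared core: compound 3 to compound 4

The compounds below may be only part of what the source reports. "The series", "measured", "known", "first", "only" and "open" are said of these compounds alone.

Compound 1, `COc1ccc(/C=C/C(=O)O[C@@H]2C[C@@](O)(CO)[C@H]3[C@H](O[C@@H]4O[C@H](CO)[C@@H](O)[C@H](O)[C@H]4O)OC=C[C@H]32)cc1O`, gives 3900 nM in a functional assay for inhibition, read by fluorescence, with a stated time of 5 min, in the presence of a further agent that is not named here; on this read-out lower numbers stand for stronger inhibition and higher numbers for weaker inhibition.
Compound 2, `C[C@]1(O)C[C@@H](OC(=O)c2ccc(O)cc2)[C@@H]2CCO[C@@H](O[C@@H]3O[C@H](CO)[C@@H](O)[C@H](O)[C@H]3O)[C@@H]21`, gives 8300 nM in this assay.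
Compound 3, `O=C(C/C=C/c1ccc(O)cc1)OC[C@@]1(O)CO[C@@H](O[C@H]2[C@H](OCCc3ccc(O)cc3)O[C@H](CO)[C@@H](O)[C@@H]2O)[C@@H]1O`, gives 4500 nM in this assay.

Compound 3 stands second highest of the three numbers; its nearest neighbour is compound 1 and its furthest is compound 2, and both gaps lie within the scatter, so no order among the three is drawn. Compound 4, `O=C(OC[C@@]1(O)CO[C@@H](O[C@H]2[C@H](OCCc3ccc(O)cc3)O[C@H](CO)[C@@H](O)[C@@H]2O)[C@@H]1O)c1ccc(O)cc1`, is not yet measured. It differs from compound 3 in one place: 4-hydroxyphenyl in place of 3-(4-hydroxyphenyl)prop-2-en-1-yl on a carbonyl carbon. Among the compounds with values here, no pair of measured compounds isolates this change. Compound 2 carries the same entering group as compound 4 and sits at the higher end of the three numbers, but on a different core. The step from compound 3 to compound 4 is expected to be small and toward a higher number, a 1.3-fold higher number from compound 3 to compound 4 (0.12 log units; within the scatter), likely within the scatter. Compound 4 is therefore estimated at 6000 nM in this assay, with a range from 2500 nM to 14000 nM.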

Compound 4, half-maximal inhibitory concentration: 36200 nM
For compound 4 the middle estimate is 6.0-fold (0.78 log units) below the measured one; the measured number lies above the stated range.
By their numbers in this assay, from the lowest: compounds 1, 3 and 2 (each within the scatter of the next, the first and the last beyond it); then compound 4.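

On the carbonyl carbon of the shared core, 4-hydroxyphenyl in place of 3-(4-hydroxyphenyl)prop-2-en-1-yl gives an 8.0-fold higher number from compound 3 to compound 4 (0.91 log units; beyond the scatter) in this assay, the first single-place step read in this series. Inhibition at this position therefore depends on the acyl group, and the shorter group goes with the weaker inhibition. No measurement shown accounts for this step.

The double bond and chain length remain unseparated; a saturated propyl chain bearing the same 4-hydroxyphenyl would separate them. On these data alone, a carboxylic acid in place of the ring hydroxyl also remains open.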